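The source may report more compounds than this note shows. Statements on the series, on what has been measured and on what is new or still open speak of the compounds shown alone.

Compound 1 `Cc1cc2c(c(=O)[nH]1)OC(C(=O)CC(C)C)O2` is one of two compounds examined in a functional assay on HCT-116 cells (Homo sapiens) for cytotoxicity, read by WST assay, with a stated time of 48 h; on this read-out lower numbers stand for stronger inhibition and higher numbers for weaker inhibition. In this assay compound 1 gives > 100000 nM, which is a limit of the assay and not a number. Compound 2 `CC1=CC(=O)[C@]2(O[C@@H]2C(=O)CC(C)C)C(=O)N1` belongs to the same set, but in this assay compound 2 has "not determined" (no result reported). Compound 1 thus stands only at the limit of > 100000 nM in this assay, at which 1 of the 2 values shown sits, and no single number places it anywhere else. Compound 3 `CC(C)CC(=O)C1Oc2cc(Cc3ccccc3)[nH]c(=O)c2O1` is the next compound to be measured in this assay. It differs from compound 1 by phenyl in place of hydrogen on a saturated chain carbon bound to an aromatic carbon. Going by the values given here, no step between measured compounds is available here, so what can be said of the change rests on the structure alone. Compound 3 is expected to show a step of an at least 1.2-fold lower number from compound 1 to compound 3 (0.09 log units; that floor lies within the scatter), with a fair chance that the assay again reports only a limit. For compound 3 the expected value in this assay is 80000 nM, within a range from 20000 nM to 200000 nM.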

Compound 3, half-maximal inhibitory concentration: > 100000 nM
Compound 3 gave a limit, no number (the forecaster's own chance of this, stated with the estimate: 55%); at least 1.2-fold (0.09 log units) between middle value and limit.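

For compound 3 the result of > 100000 nM is a limit of the assay and not a number. Going by these compounds alone, no step between compound 1 and compound 3 can be read, as both stand at the same limit: the limit of > 100000 nM in this assay, at which 2 of the 3 values shown sit. The compounds shown leave open whether phenyl in place of hydrogen on a saturated chain carbon bound to an aromatic carbon changes the read-out at all.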